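Methyl removal on the sugar-altered core, under flat limits

This account rests on a few compounds, and the source may have more. Where it says the series, first, only, none or still open, it means among the compounds named here.

Compound 1 `CSc1nc2c(C)nsc2n1[C@H]1C[C@H](O)[C@@H](CO)O1` was tested in a functional assay on L1210 cells (Mus musculus) for antiproliferative activity; on this read-out lower numbers stand for stronger inhibition and higher numbers for weaker inhibition. In that assay compound 1 gives > 100000 nM, which is a limit of the assay and not a number. Compound 2 `CSc1nc2cnsc2n1[C@H]1C[C@H](O)[C@@H](CO)O1` differs from compound 1 by hydrogen in place of methyl on an aromatic carbon. In this assay compound 2 gives > 100000 nM, again only a limit. The step that the two limits leave unreadable from compound 1 to compound 2 therefore cannot be sized. Compound 3 `CSc1nc2c(C)nsc2n1[C@@H]1O[C@H](CO)[C@@H](O)[C@H]1O` differs from compound 1 in its core by hydroxy in place of hydrogen on a saturated ring carbon. In this assay compound 3 gives > 100000 nM, also a limit, so the step that the two limits leave unreadable from compound 1 to compound 3 cannot be sized either. All three values sit at the limit of > 100000 nM in this assay, at which 3 of the 3 values shown sit. Compound 4 `CSc1nc2cnsc2n1[C@@H]1O[C@H](CO)[C@@H](O)[C@H]1O` is compound 3 carrying the same change that turns compound 1 into compound 2, (hydrogen in place of methyl on an aromatic carbon). Because every measured value rests at the limit of > 100000 nM in this assay, at which 3 of the 3 values shown sit, compound 4 is expected to show the step that the limit leaves unreadable from compound 3 to compound 4. Compound 4 is estimated to give 200000 nM in this assay, most likely again as a limit.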

Compound 4, half-maximal inhibitory concentration: > 100000 nM
Compound 4: a limit, no number; the forecaster's own chance of this, stated with the estimate: 90%; the middle value lies beyond the limit too.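

For the compounds shown here, neither the step from compound 3 to compound 4 nor the one from compound 2 to compound 4 can be read, because all four values rest on one limit: the limit of > 100000 nM in this assay, at which 4 of the 4 values shown sit. The compounds shown leave open whether either change alters activity at all.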